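Amide aryl variation on the shared core: compound 4

A few compounds are considered here, and "the series" means these few. Any claim that something is new, unique, unknown or untested is made for them only; others in the source may bear on it.

The series keeps one core, shown with compound 1 `O=C(Nc1cccc(-c2oc3cc(-c4ccc(F)cc4)ccc3c(=O)c2O)c1)c1ccc(F)cc1`, and varies the aryl group on the amide carbonyl. In a functional assay on HeLa cells (Homo sapiens) for antiproliferative activity, read by CCK-8 assay, with a stated time of 72 h (on this read-out lower numbers stand for stronger inhibition and higher numbers for weaker inhibition), compound 1 gives 5350 nM. Compound 2 `COc1ccc(C(=O)Nc2cccc(-c3oc4cc(-c5ccc(F)cc5)ccc4c(=O)c3O)c2)c(F)c1` carries a 2-fluoro-4-methoxyphenyl there and in this assay compound 2 gives 16100 nM, the step being a 3.0-fold higher number from compound 1 to compound 2 (0.48 log units; beyond the scatter). Compound 3 `O=C(Nc1cccc(-c2oc3cc(-c4ccc(F)cc4)ccc3c(=O)c2O)c1)c1cc(F)cc(F)c1` carries a 3,5-difluorophenyl; in this assay compound 3 gives 3380 nM. The step of a 1.6-fold lower number from compound 1 to compound 3 (0.20 log units; within the scatter) lies within the scatter, whereas a 4.8-fold lower number from compound 2 to compound 3 (0.68 log units; beyond the scatter) lies beyond it, so compound 3 holds the lowest number of the three but is not separated from compound 1.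

Compound 4 `N#Cc1ccc(C(=O)Nc2cccc(-c3oc4cc(-c5ccc(F)cc5)ccc4c(=O)c3O)c2)cc1` is the next member. The change from compound 3 is 4-cyanophenyl in place of 3,5-difluorophenyl on a carbonyl carbon. Going by the values given here, no measured step involves a cyanophenyl, so the expectation rests on the three amide aryl changes already seen: one within the scatter and two of modest size in opposite directions. Compound 4 is therefore expected to fall close to compound 3, with a 1.6-fold higher number from compound 3 to compound 4 (0.21 log units; within the scatter) as the estimated step, most likely a slightly higher number. The estimate for compound 4 in this assay is 5500 nM, with a range from 2000 nM to 15000 nM.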

Compound 4, half-maximal inhibitory concentration: 23300 nM
Estimate against measurement, compound 4: 4.2-fold (0.63 log units) below; measured number above the stated range.
By their numbers in this assay, from the lowest: compounds 3 and 1 (each within the scatter of the next); then compounds 2 and 4 (each within the scatter of the next).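

Within this assay, a 6.9-fold higher number from compound 3 to compound 4 (0.84 log units; beyond the scatter) is a clear move at the amide aryl position, showing that exchanging one aryl group for another of the same heavy-atom size on this carbonyl carbon can shift the number beyond the scatter. The step of a 4.4-fold higher number from compound 1 to compound 4 (0.64 log units; beyond the scatter) is the tightest comparison so far. Cyano in place of fluoro on an aromatic carbon is the only change and it alone takes the number beyond the scatter, so the outcome at this position depends on the identity of that single substituent and not merely on the presence of a substituted phenyl ring. By contrast, a 1.4-fold higher number from compound 2 to compound 4 (0.16 log units; within the scatter) stays within the scatter, so 4-cyanophenyl and 2-fluoro-4-methoxyphenyl are not separated here, and both stand apart from the 4-fluorophenyl of compound 1 and the 3,5-difluorophenyl of compound 3.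

Going by these compounds, how an unsubstituted phenyl, an aminophenyl or a carboxyphenyl on the same carbonyl carbon would compare with these four remains open. No supporting data bear on why the cyano-bearing compound gives the number it does.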